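From Acid to Amide: Following Compound 1 to Compound 4

The source may hold more compounds than are shown below. What is called first, only, known or untested is meant among the compounds shown, and "the series" means these compounds.

In a functional assay on CHO cells for agonist activity at Free fatty acid receptor 1 (Homo sapiens), read by a luciferase reporter (on this read-out lower numbers stand for smaller maximal responses and higher numbers for larger maximal responses), compound 1 `Cc1nc(-c2ccc(C(F)(F)F)cc2)sc1CNc1ccc(/C=C/C(=O)O)cc1` gives 95%, the highest of the two single numbers available. Compound 3 `CC(Cc1ccc(NCc2cccc(Oc3ccccc3)c2)cc1)C(=O)O`, built on a different core, gives 70% in this assay, a gap beyond the usual scatter. Compound 2 `O=C(O)[C@H]1C[C@@H]1c1ccc(NCc2cccc(Oc3ccccc3)c2)cc1` has been read more than once in this assay, giving 88%; 72% (2 entries); the spread between those repeats (the several entries of compound 2 in this assay, 88%; 72% (2 entries)) shows how far two readings of one compound can lie apart.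

Compound 4 `Cc1nc(-c2ccc(C(F)(F)F)cc2)sc1CNc1ccc([C@H]2C[C@@H]2C(=O)NC2CCNC2)cc1` is reached from compound 1 by a single change (2-((pyrrolidin-3-yl)carbamoyl)cyclopropyl in place of 2-carboxyethenyl on an aromatic carbon). No measured pair among these compounds shows a change of this kind, so its effect has to be judged without a direct precedent. The author expects the step from compound 1 to compound 4 in this assay to point downward and to exceed the scatter, a number 35 percentage points lower from compound 1 to compound 4 (beyond the scatter), though with wide uncertainty. For compound 4 the estimated maximal response is 60%, expected to fall between 15% and 100%.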

Compound 4, largest response reached (reported as percent of maximum), in percent of the reference or control that the assay uses: 52%
For compound 4 the middle estimate is 8 percentage points above the measured one, within the range that was stated.
By their numbers in this assay, from the lowest: compound 4; then compound 3; then compound 1.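

At this place on the aromatic ring, para to a large group, exchanging 2-carboxyethenyl for 2-((pyrrolidin-3-yl)carbamoyl)cyclopropyl gives in this assay a first measured step: a number 43 percentage points lower from compound 1 to compound 4 (beyond the scatter). Compound 4 is the only compound shown without a carboxylic acid, so this position is seen to tolerate an acid-free group with a reduced response rather than none, compound 4 giving 52%. The step is also wider than the gap between repeated readings of a single compound: the several entries of compound 2 in this assay, 88%; 72% (2 entries)

The exchange alters several things at once, and the compounds shown do not tell which part carries the step. A cyclopropane bearing a free carboxylic acid on the core of compound 1, or a plain amide without the pyrrolidine, would separate those parts.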